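The source may report more compounds than this note shows. Statements on the series, on what has been measured and on what is new or still open speak of the compounds shown alone.

Compound 1 `Oc1cccc2ccc(Sc3ccccn3)nc12`: 20900 nM
Compound 2 `Oc1ccc(Cl)c2ccc(Sc3ccccn3)nc12`: 10200 nM
Compound 3 `Oc1ccc(Br)c2ccc(Sc3ccccn3)nc12`: not yet measured

Among the compounds with values here, in a functional assay on PC-3 cells (Homo sapiens) for antiproliferative activity, read by MTT assay, with a stated time of 96 h (a lower number here means a stronger inhibitor of growth, a higher number a weaker inhibitor of growth), compound 2, at 10200 nM, holds the lower of the two numbers so far. The next change is small: compound 3 carries bromo in place of chloro on an aromatic carbon, para to a hydroxy group (bromo in place of chloro on an aromatic carbon). Within the data shown here, only one measured step bears on this, and it is a 2.0-fold lower number from compound 1 to compound 2 (0.31 log units; beyond the scatter), which came from putting chloro in place of hydrogen on an aromatic carbon. That step is modest and only just clears the scatter. Exchanging one halogen for another is a smaller structural change than adding one, so no step beyond the scatter is expected in this assay. The expected change is a 1.1-fold lower number from compound 2 to compound 3 (0.05 log units; within the scatter). For compound 3 the estimated value is 9000 nM, with an expected range of 4500 nM to 18000 nM.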

Compound 3, concentration for 50% growth inhibition: 10200 nM
Beside the measured number, compound 3's estimate is 1.1-fold (0.05 log units) below it; the measured number falls inside the stated range.
By their numbers in this assay, from the lowest: compounds 2 and 3 (each within the scatter of the next); then compound 1.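

In this assay bromo in place of chloro at this carbon, para to a hydroxy group, gives no change at the digits printed from compound 2 to compound 3 (within the scatter) and so the two halogens cannot be told apart at this position. Bromo in place of hydrogen on the same carbon gives a 2.0-fold lower number from compound 1 to compound 3 (0.31 log units; beyond the scatter) and this modest step is the same size as the one seen with chloro, which shows that the shift from compound 1 is not tied to chloro alone. Nothing measured here explains why the two halogens read alike.

Going by these compounds, whether this carbon needs a halogen at all stays open, since a methyl, a methoxy or an amine in the same place could read differently. On these data alone, it is also open whether fluoro or iodo would follow chloro and bromo.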